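Fluoro for trifluoromethyl on the sulfonyl aryl ring

The source may report more compounds than this note shows. Statements on the series, on what has been measured and on what is new or still open speak of the compounds shown alone.

Of the compounds shown here, two share a core and have been measured in a functional assay on HeLa cells for agonist activity at 5-hydroxytryptamine receptor 6 (Homo sapiens), read by cAMP accumulation and immunoassay; on this read-out lower numbers stand for an effect already at smaller amounts and higher numbers for an effect only at larger amounts of compound. Compound 1, `CN1CCC(n2cc(S(=O)(=O)c3cccc(F)c3)c3cccnc32)C1`, gives 231 nM in this assay. Compound 2, `CN1CCCC(n2cc(S(=O)(=O)c3cccc(C(F)(F)F)c3)c3cccnc32)C1`, gives 49 nM in this assay, the lower of the two numbers, and the gap to compound 1 lies beyond the scatter. Among the compounds with values here, compound 1 and compound 2 differ in more than one place, so no single step between them can be read.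

Compound 3, `CN1CCCC(n2cc(S(=O)(=O)c3cccc(F)c3)c3cccnc32)C1`, is the next compound. It differs from compound 2 in one place: fluoro in place of trifluoromethyl on an aromatic carbon. Within the data shown here, no measured pair shows this change on its own. Since compound 1 carries the same fluoro group and gives 231 nM, compound 3 is expected to move toward a higher number than compound 2, by a step of a 2.4-fold higher number from compound 2 to compound 3 (0.39 log units; beyond the scatter) of modest size that may exceed the scatter. Compound 3 is estimated at 120 nM in this assay, within 40 nM to 350 nM.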

Compound 3, half-maximal effective concentration: 306 nM
The estimate for compound 3 lay 2.6-fold (0.41 log units) below the measured number, and the stated range covers the measured number.
By their numbers in this assay, from the lowest: compound 2; then compounds 1 and 3 (each within the scatter of the next).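

Read on its own for the first time, fluoro in place of trifluoromethyl on the aromatic carbon gives a 6.2-fold higher number from compound 2 to compound 3 (0.80 log units; beyond the scatter) in this assay, so at this place on the sulfonyl aryl ring the lower number goes with trifluoromethyl. With fluoro on that ring, 1-methylpiperidin-3-yl in place of 1-methylpyrrolidin-3-yl on the aromatic nitrogen gives a 1.3-fold higher number from compound 1 to compound 3 (0.12 log units; within the scatter) and does not separate the two compounds, so the gap between compound 1 and compound 2 follows the aryl substituent rather than the ring on the nitrogen. Nothing on hand explains why the two aryl substituents differ.

The compounds shown leave open where a nitrile, a methoxy group or a chlorine at this place would fall relative to fluoro and trifluoromethyl. They also leave open whether the two nitrogen substituents would stay as close with trifluoromethyl on the aryl ring.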